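The source may hold more compounds than are shown below. What is called first, only, known or untested is meant among the compounds shown, and "the series" means these compounds.

Three compounds have been measured so far in a functional assay on K562 cells (Homo sapiens) for cytotoxicity, in the presence of a further agent that is not named here; on this read-out higher numbers stand for weaker inhibition and lower numbers for stronger inhibition:

compound 1 `Clc1cccc(-c2cc(-c3ccc(Cl)o3)cc(-c3cccs3)n2)c1`: 19800 nM
compound 2 `Clc1ccc(-c2cc(-c3cccs3)nc(-c3ccccc3Cl)c2)o1`: 17200 nM
compound 3 `Cc1ccc(-c2cc(-c3ccc(Cl)o3)cc(-c3ccsc3)n2)o1`: 23300 nM

Compound 3 stands at the highest of the three numbers, yet its gap to compound 1 and its gap to compound 2 both fall within the scatter, so the three compounds cannot be told apart on this assay. Among the measured compounds shown here, the one measured single-point step, a 1.2-fold lower number from compound 1 to compound 2 (0.06 log units; within the scatter), concerns 2-chlorophenyl in place of 3-chlorophenyl and stays within the scatter as well.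

Compound 4 `Clc1ccc(-c2cc(-c3ccsc3)nc(-c3ccco3)c2)o1` has not yet been measured. It differs from compound 3 in one place: hydrogen in place of methyl on an aromatic carbon. For the measured compounds named here, no measured step concerns a methyl leaving for hydrogen, so the measured compounds offer no direct guide; the only step available, a 1.2-fold lower number from compound 1 to compound 2 (0.06 log units; within the scatter), is itself within the scatter. Compound 4 is therefore expected to give about 22000 nM in this assay, within a range from 9000 nM to 50000 nM. That estimate amounts to an expected step of a 1.1-fold lower number from compound 3 to compound 4 (0.02 log units; within the scatter), no larger than the scatter.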

Compound 4, half-maximal inhibitory concentration: 22400 nM
For compound 4 the middle estimate is 1.0-fold (0.01 log units) below the measured one; measured number inside the range.
By their numbers in this assay, from the lowest: compounds 2, 1, 4 and 3 (each within the scatter of the next).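

In this assay, the change from 5-methylfuran-2-yl to furan-2-yl (a 1.0-fold lower number from compound 3 to compound 4 (0.02 log units; within the scatter)) stays within the scatter. Among the compounds shown here, this is the first reading at this place, the aromatic carbon next to the ring oxygen, and it shows that the methyl can be replaced by hydrogen without a step beyond the scatter, so compound 3 and compound 4 cannot be told apart on this read-out. No evidence is available that would explain this result.

From the compounds shown here alone, whether another group at this place, such as an amine, a carboxylic acid or a longer chain, would give a step beyond the scatter remains open. The compounds shown also leave open whether any single change to this series can give such a step in this assay.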